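Methoxy in place of chloro: compound 3 to compound 4

The source may hold more compounds than are shown below. What is called first, only, known or untested is meant among the compounds shown, and "the series" means these compounds.

Compound 1 `CCOC(=O)C(=O)CC(=O)/C=C/c1cn(Cc2ccc(OC)cc2)c2ccccc12`: "not determined" (no result reported)
Compound 2 `C=C(C)Cn1cc(/C=C/C(=O)CC(=O)C(=O)O)c2ccccc21`: 40000 nM
Compound 3 `O=C(/C=C/c1cn(Cc2ccc(Cl)cc2)c2ccccc12)CC(=O)C(=O)O`: > 40000 nM (a limit)

In an ADME assay on HeLa cells (Homo sapiens) for inhibition, read by MTT assay, with a stated time of 48 h (on this read-out lower numbers stand for stronger inhibition and higher numbers for weaker inhibition), compound 3 has only a limit, > 40000 nM, and no single number. Compound 4 `COc1ccc(Cn2cc(/C=C/C(=O)CC(=O)C(=O)O)c3ccccc32)cc1` differs from it as follows: methoxy in place of chloro on an aromatic carbon. This places methoxy in place of chloro on an aromatic carbon, para to a large group. Going by the values given here, the only measured step that bears on this change is a number no lower from compound 2 to compound 3 (the limit leaves the size open), and it replaces the whole 4-chlorophenyl group, so it offers only weak guidance. No step beyond the scatter is expected in this assay, and no direction can be assigned. The expected change is a number no higher from compound 3 to compound 4 (the limit leaves the size open). For compound 4 the estimated value is 40000 nM, with an expected range from 15000 nM to 80000 nM.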

Compound 4, half-maximal inhibitory concentration: > 40000 nM
Compound 4 was reported as a limit (the forecaster's own chance of this, stated with the estimate: 55%); the middle value lies on the limit itself.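

In this assay compound 4 gives only a limit, > 40000 nM. The step for methoxy in place of chloro on an aromatic carbon, para to a large group, cannot be read, because both values are limits: the limit of > 40000 nM in this assay, at which 2 of the 4 values shown sit.

With 4-methoxyphenyl in place of 1-methylethenyl, the result is a number no lower from compound 2 to compound 4 (the limit leaves the size open).

On these data alone, the values of the 4-chlorobenzyl and 4-methoxybenzyl compounds beyond the limit remain open. Also open, as far as these compounds go, is whether an amine on that aromatic ring, or a longer chain on the aromatic nitrogen, would give a single number in this assay.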